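Swapping the sulfonyl aryl group in an EP3 antagonist series

This account rests on a few compounds, and the source may have more. Where it says the series, first, only, none or still open, it means among the compounds named here.

Compound 1 `COc1ccc(Cl)cc1S(=O)(=O)NC(=O)NC/C=C1\CCCc2cnn(Cc3ccc(Cl)cc3Cl)c21` is the stronger of the two measured compounds: in an assay on isolated protein for displacement of a labelled ligand from prostaglandin E2 receptor EP3 subtype (Homo sapiens), read by scintillation counting, with a stated time of 2 h (a higher number here means a weaker inhibitor, a lower number a stronger inhibitor), compound 1 gives 3 nM, while compound 2 `O=C(NS(=O)(=O)c1ccc(Cl)cc1)OC/C=C1\CCCc2cnn(Cc3ccc(Cl)cc3Cl)c21` gives 11 nM in this assay. Compound 3 `Cc1ncc(S(=O)(=O)NC(=O)NC/C=C2\CCCc3cnn(Cc4ccc(Cl)cc4Cl)c32)s1` differs from compound 1 by 2-methyl-1,3-thiazol-5-yl in place of 5-chloro-2-methoxyphenyl on a sulfonyl sulfur. Among the measured compounds shown here, no measured pair isolates this change, so its effect is unknown. A modest rise in the number, possibly beyond the scatter, is expected, giving a 3.3-fold higher number from compound 1 to compound 3 (0.52 log units; beyond the scatter). Compound 3 is therefore estimated at 10 nM in this assay, with a range from 2.5 nM to 40 nM.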

Compound 3, inhibition constant: 7 nM
Compound 3: middle estimate off by 1.4-fold (0.15 log units), on the high side; the measured number falls inside the stated range.
By their numbers in this assay, from the lowest: compound 1; then compounds 3 and 2 (each within the scatter of the next).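

On the sulfonyl sulfur, 2-methyl-1,3-thiazol-5-yl can replace 5-chloro-2-methoxyphenyl at only a modest cost in this assay, with a 2.3-fold higher number from compound 1 to compound 3 (0.37 log units; beyond the scatter). This position therefore tolerates a five-membered aromatic ring with 2 hetero atoms and fewer heavy atoms, as compound 3 still gives 7 nM in the low nanomolar range. No evidence here accounts for the step.

The whole aryl group changes at once, leaving the separate contributions of the chlorine, the methoxy and the thiazole methyl unresolved. From the compounds shown here alone, it also remains open how an unsubstituted phenyl or a simple alkyl chain on the sulfonyl sulfur would compare.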